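The source may report more compounds than this note shows. Statements on the series, on what has been measured and on what is new or still open speak of the compounds shown alone.

Compound 1 `Cc1nn(C)c(Oc2ccc(Cl)cc2)c1/C=N\CCCCCOc1cc2oc(=O)cc(C)c2cc1Cl` and compound 2 `Cc1nn(C)c(Oc2ccc(I)cc2)c1/C=N\CCCCCOc1cc2oc(=O)cc(C)c2cc1Cl` share one core and differ in a single place. In a functional assay on HepG2 cells (Homo sapiens) for antiproliferative activity, read by MTT assay, with a stated time of 72 h (on this read-out lower numbers stand for stronger inhibition and higher numbers for weaker inhibition), compound 1 gives 15300 nM. For compound 2 this assay reports only a limit, > 25000 nM. Accordingly the step of an at least 1.6-fold higher number from compound 1 to compound 2 (0.21 log units; that floor lies within the scatter) cannot be sized further, and compound 2 stands at the limit of > 25000 nM in this assay, at which 1 of the 2 values shown sits. Compound 3 `Cc1ccc(Oc2c(/C=N\CCCCCOc3cc4oc(=O)cc(C)c4cc3Cl)c(C)nn2C)cc1` carries methyl in place of iodo on an aromatic carbon. Going by the values given here, only that one measured step bears on this change, and it lies within the scatter, so no step beyond the scatter is expected here. The value of compound 3 is estimated at 20000 nM, between 8000 nM and 50000 nM, which would mean an expected step of an at least 1.2-fold lower number from compound 2 to compound 3 (0.09 log units; that floor lies within the scatter).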

Compound 3, half-maximal inhibitory concentration: 10300 nM
The estimate for compound 3 lay 1.9-fold (0.29 log units) above the measured number, within the range that was stated.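

In this assay, replacing 4-iodophenyl with 4-methylphenyl gives an at least 2.4-fold lower number from compound 2 to compound 3 (0.38 log units; beyond the scatter), the only step shown here that clears the scatter. On these data alone, its true size stays unknown, since compound 2 is known only by a limit: the limit of > 25000 nM in this assay, at which 1 of the 3 values shown sits. Methyl and chloro at this place cannot be told apart, with a 1.5-fold lower number from compound 1 to compound 3 (0.17 log units; within the scatter).

The compounds shown leave open how far iodo really lies from methyl and chloro. They also leave open whether an amine, a carboxylic acid or a methoxy group at this place would move the number beyond the scatter.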